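This account rests on a few compounds, and the source may have more. Where it says the series, first, only, none or still open, it means among the compounds named here.

Working notes on the series. The shared core carries an anilino group; in a functional assay on MGC-803 cells (Homo sapiens) for inhibition, read by MTT assay, with a stated time of 72 h (a higher number here means a weaker inhibitor, a lower number a stronger inhibitor), compound 1 `C=CC(=O)Nc1cccc(NC(=O)CSc2nc(Nc3ccccc3)c3ccccc3n2)c1` gives 7310 nM, the lowest of the two numbers shown. Compound 2 `O=C(CSc1nc(Nc2ccccc2)c2ccccc2n1)Nc1ccc(F)c(Cl)c1` gives 20900 nM in this assay. Going by the values given here, the only measured step, a 2.9-fold higher number from compound 1 to compound 2 (0.46 log units; beyond the scatter), replaces 3-((vinylcarbonyl)amino)phenyl on the amide-type nitrogen with 3-chloro-4-fluorophenyl and leaves the anilino side untouched. Compound 3 `C=CC(=O)Nc1cccc(NC(=O)CSc2nc(Nc3cccc(Cl)c3)c3ccccc3n2)c1` is not yet measured in this assay. It differs from compound 1 by chloro in place of hydrogen on an aromatic carbon of the six-membered carbon ring, so that anilino becomes (3-chlorophenyl)amino. Among the compounds with values here, no measured step bears directly on this change; the step from compound 1 to compound 2 alters the other end of the molecule and gives no guide to a chloro added here. With nothing comparable to draw on, the expectation for compound 3 in this assay is a number close to that of compound 1, the step of a 1.0-fold higher number from compound 1 to compound 3 (0.01 log units; within the scatter) being expected not to go beyond the scatter in either direction. Compound 3 is accordingly estimated at 7500 nM, between 3500 nM and 16000 nM.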

Compound 3, half-maximal inhibitory concentration: 7830 nM
Beside the measured number, compound 3's estimate is 1.0-fold (0.02 log units) below it, and the stated range covers the measured number.
By their numbers in this assay, from the lowest: compounds 1 and 3 (each within the scatter of the next); then compound 2.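

In this assay, going by these compounds alone, the one reading on the anilino side is a 1.1-fold higher number from compound 1 to compound 3 (0.03 log units; within the scatter) and so shows that chloro in place of hydrogen on this aromatic carbon, turning anilino into (3-chlorophenyl)amino, gives a step that cannot be told from the scatter. The earlier step, a 2.9-fold higher number from compound 1 to compound 2 (0.46 log units; beyond the scatter) on replacing the group on the amide-type nitrogen, lies beyond the scatter, so among the compounds shown a step of that kind is seen only at that end of the molecule and not at this position. Nothing available explains the result at this position.

A single chloro does not show how this position would respond to a larger or differently charged group, such as methoxy, an amine or a carboxylic acid, or how chloro would read on another carbon of the same ring. Going by these compounds, it also remains open whether (3-chlorophenyl)amino would read the same alongside the 3-chloro-4-fluorophenyl group on the amide-type nitrogen.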